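Cytotoxicity notes on a benzofuran-linked ether amidine series

The source may report more compounds than this note shows. Statements on the series, on what has been measured and on what is new or still open speak of the compounds shown alone.

Measured so far:
compound 1 `CC(C)NC(=N)c1ccc2oc(-c3cccc(OCCCCCCOc4ccccc4)c3)cc2c1` gives 7400 nM
compound 2 `c1ccc(OCCCCCCOc2cccc(-c3cc4cc(C5=NCCN5)ccc4o3)c2)cc1` gives 2500 nM
compound 3 `CC(C)NC(=N)c1ccc2cc(-c3ccc(OCCCOc4ccccc4)cc3)oc2c1` gives 49900 nM

In an ADME assay on L6 cells (Rattus norvegicus) for cytotoxicity, read by resazurin assay, with a stated time of 70 h (on this read-out lower numbers stand for stronger inhibition and higher numbers for weaker inhibition), compound 3 stands highest of the three measured numbers. For the measured compounds named here, the one change measured within the set is a group of 5 heavy atoms (3 carbon, 2 nitrogen; one five-membered non-aromatic ring with 2 hetero atoms) in place of a group of 6 heavy atoms (4 carbon, 2 nitrogen; no ring), on an aromatic carbon; it made a 3.0-fold lower number from compound 1 to compound 2 (0.47 log units; beyond the scatter). The same change, (a group of 5 heavy atoms (3 carbon, 2 nitrogen; one five-membered non-aromatic ring with 2 hetero atoms) in place of a group of 6 heavy atoms (4 carbon, 2 nitrogen; no ring), on an aromatic carbon), turns compound 3 into the unmeasured compound 4 `c1ccc(OCCCOc2ccc(-c3cc4ccc(C5=NCCN5)cc4o3)cc2)cc1`. The two place lines agree word for word, so this is the same change on a different core; how the core of compound 3 differs from the core of compound 1 is not broken down here. For compound 4 in this assay a step of about the size seen from compound 1 to compound 2 is expected, resting only on that single pair, a 3.0-fold lower number from compound 3 to compound 4 (0.48 log units; beyond the scatter). Compound 4 is estimated at 16600 nM, between 6000 nM and 45000 nM.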

Compound 4, half-maximal inhibitory concentration: 16800 nM
Estimate against measurement, compound 4: 1.0-fold (0.01 log units) below, and the stated range covers the measured number.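

In this assay, putting the five-membered non-aromatic ring group in place of the ringless group of 6 heavy atoms gives a 3.0-fold lower number from compound 3 to compound 4 (0.47 log units; beyond the scatter), and this matches the step seen on the core of compound 1: the same change on two cores in this assay, a 3.0-fold lower number (0.47 log units; beyond the scatter) from compound 1 to compound 2 and a 3.0-fold lower number (0.47 log units; beyond the scatter) from compound 3 to compound 4, 1.0-fold (0.00 log units) apart, within the scatter of two such steps

The change therefore carries across these two cores with no measurable difference in step size. For the compounds shown here, with only two pairs, this is agreement between those pairs rather than a rule for the series, and it does not separate the contributions of the cores, as compound 1 and compound 3 differ in more than one place.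

From the compounds shown here alone, it remains open whether an unsubstituted amidine or a six-membered cyclic amidine would behave alike. Going by these compounds, the shares of the chain and the rest of the core in the gap between compound 1 and compound 3 also remain open.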